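This account rests on a few compounds, and the source may have more. Where it says the series, first, only, none or still open, it means among the compounds named here.

Measured compounds in an in vitro ADME assay on the whole organism (small intestine) for pharmacokinetics, with Rattus norvegicus as the target; on this read-out higher numbers stand for a longer-lived compound and lower numbers for a shorter-lived compound:
- compound 1 `C/C(=C\c1ccc(C(=O)Oc2ccc(C(=N)N)cc2)cc1)C(=O)N(CC(=O)O)Cc1ccccc1` gives 0.833 h
- compound 2 `CCOC(=O)CN(Cc1ccccc1)C(=O)/C(C)=C/c1ccc(C(=O)Oc2ccc(C(=N)N)cc2)cc1` gives 0.733 h
- compound 3 `CCOC(=O)CN(C(=O)/C(C)=C/c1ccc(C(=O)Oc2ccc(C(=N)N)cc2)cc1)C1CCCC1` gives a value that is a limit of the assay, > 1 h

Compound 1 is one of two compounds with a number rather than a limit; the step of a 1.1-fold lower number from compound 1 to compound 2 (0.06 log units; within the scatter) separates them, so the two are not distinguished. The third value sits at the limit of > 1 h in this assay, at which 1 of the 3 values shown sits, and is not a number.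

Compound 4 `C/C(=C\c1ccc(C(=O)Oc2ccc(C(=N)N)cc2)cc1)C(=O)N(CC(=O)O)C1CCCCC1` is not yet measured. It differs from compound 1 in one place: cyclohexyl in place of benzyl on an amide-type nitrogen. Among the measured compounds shown here, the only measured step of the same kind is an at least 1.3-fold higher number from compound 2 to compound 3 (0.13 log units; that floor lies within the scatter), a change on the same amide-type nitrogen from benzyl to a saturated ring, which gave a floor rather than a number and stayed within the scatter. On that basis no step beyond the scatter is expected for compound 4, with a lean toward a somewhat longer half-life.

The estimate for compound 4 is 1 h (range 0.6 h to 1.8 h), which corresponds to an expected step of a 1.2-fold higher number from compound 1 to compound 4 (0.08 log units; within the scatter).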

Compound 4, half-life: 0.817 h
The estimate for compound 4 lay 1.2-fold (0.09 log units) above the measured number, within the range that was stated.
By their numbers in this assay, from the lowest: compounds 2, 4 and 1 (each within the scatter of the next). At a limit, above all of these: compound 3.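

In this assay, the change from benzyl to cyclohexyl on the amide-type nitrogen gives a 1.0-fold lower number from compound 1 to compound 4 (0.01 log units; within the scatter), so with the carboxylic acid kept, the aromatic and non-aromatic rings are not told apart at this position. This pair gives a number on both sides of such a change, which the earlier change from benzyl to a saturated ring on this nitrogen did not. Compound 3 remains a limit and not a number: the limit of > 1 h in this assay, at which 1 of the 4 values shown sits.

Still open, going by these compounds, is whether an aminoethyl group or a longer chain such as n-hexyl in place of benzyl on this nitrogen would give a step beyond the scatter. Also open, on these data alone, is how the ethyl ester of compound 4 would compare with compound 4 itself.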